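The source may report more compounds than this note shows. Statements on the series, on what has been measured and on what is new or still open speak of the compounds shown alone.

In a toxicity assay on L02 cells (Homo sapiens) for cytotoxicity, read by MTT assay, with a stated time of 24 h (a higher number here means that more compound is tolerated, a lower number that less compound is tolerated), compound 1 `CCCOC(=O)/C=C/c1ccc(OS(=O)(=O)c2ccc(Cl)cc2)c(OC)c1` gives 150000 nM, and compound 3 `CCOC(=O)/C=C/c1ccc(OS(=O)(=O)c2ccc(Cl)cc2)c(OC)c1` gives 137000 nM. Compound 2 `COc1cc(/C=C/C(=O)Nc2cccc(C)c2)ccc1OS(=O)(=O)c1ccc(Cl)cc1` gives 73500 nM, the lowest of the three numbers: the step of a 2.0-fold lower number from compound 1 to compound 2 (0.31 log units; beyond the scatter) lies beyond the scatter, whereas a 1.9-fold higher number from compound 2 to compound 3 (0.27 log units; within the scatter) stays within it. Compound 4 `CCCCS(=O)(=O)Oc1ccc(/C=C/C(=O)Nc2cccc(C)c2)cc1OC` differs from compound 2 in one place: butyl in place of 4-chlorophenyl on a sulfonyl sulfur. Among the compounds with values here, none of the measured steps touches the sulfonyl sulfur, since a 1.1-fold lower number from compound 1 to compound 3 (0.04 log units; within the scatter) and a 2.0-fold lower number from compound 1 to compound 2 (0.31 log units; beyond the scatter) both alter only the carbonyl side of the shared core, so nothing measured bears directly on this exchange. No step beyond the scatter is therefore expected. Compound 4 is estimated at 80000 nM, with a range from 35000 nM to 180000 nM. That estimate corresponds to an expected step of a 1.1-fold higher number from compound 2 to compound 4 (0.04 log units; within the scatter).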

Compound 4, half-maximal cytotoxic concentration: 33600 nM
Compound 4: the middle estimate sits 2.4-fold (0.38 log units) above what was measured, and the stated range ends above it.
By their numbers in this assay, from the lowest: compound 4; then compounds 2, 3 and 1 (each within the scatter of the next, the first and the last beyond it).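

Within the data shown here, on the sulfonyl sulfur, butyl in place of 4-chlorophenyl gives a 2.2-fold lower number from compound 2 to compound 4 (0.34 log units; beyond the scatter) in this assay and so shows that this position, untouched by the earlier steps, can shift the number beyond the scatter. With the butyl group, less compound is tolerated, even though the carbonyl side stays as in compound 2. Nothing available explains this change. On these data alone, it remains open how a methyl group, a longer chain such as octyl or an unsubstituted phenyl would read on the same sulfur. As far as these compounds go, the same exchange on the esters compound 1 and compound 3 also remains open.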